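Compound 2 to compound 3: nitro for chloro

This account rests on a few compounds, and the source may have more. Where it says the series, first, only, none or still open, it means among the compounds named here.

In a functional assay on MCF7 cells (Homo sapiens) for cytotoxicity, read by MTT assay, with a stated time of 72 h (a higher number here means a weaker inhibitor, a lower number a stronger inhibitor), compound 2 (`O=C(CCc1ccc(NC(=O)Nc2ccc(Cl)cc2)cc1)NO`) gives > 50000 nM as a limit of the assay and not a number. Compound 1 (`O=C(Nc1ccc(C(=O)NO)cc1)Nc1ccc([N+](=O)[O-])cc1`) gives > 50000 nM as a limit as well. Going by the values given here, the series so far shows the limit of > 50000 nM in this assay, at which 2 of the 2 values shown sit, and holds no measured number. Compound 3 (`O=C(CCc1ccc(NC(=O)Nc2ccc([N+](=O)[O-])cc2)cc1)NO`) carries nitro in place of chloro on an aromatic carbon, para to a large group (nitro in place of chloro on an aromatic carbon). Nitro also stands on compound 1, whose reading is that same limit. Among the compounds with values here, no step between measured compounds is available, so no step size can be read from the data. In this assay no step beyond the scatter is expected for this change. The expected step is a number no higher from compound 2 to compound 3 (the limit leaves the size open) on this estimate. For compound 3 the estimated value is 50000 nM with an expected range from 15000 nM to 80000 nM and a reading at the limit is the likeliest outcome.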

Compound 3, half-maximal inhibitory concentration: > 50000 nM
Compound 3 ended at the assay's limit; the forecaster's own chance of this, stated with the estimate: 70%; the middle value sits exactly at the limit.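

In this assay no step from compound 2 or compound 1 to compound 3 can be read: the limit of > 50000 nM in this assay, at which 3 of the 3 values shown sit.

The compounds shown leave open whether nitro in place of chloro, or 2-(hydroxycarbamoyl)ethyl in place of hydroxycarbamoyl, changes the half-maximal inhibitory concentration at all.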